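Ethylamino in place of hydroxy: notes on compound 3

A few compounds are considered here, and "the series" means these few. Any claim that something is new, unique, unknown or untested is made for them only; others in the source may bear on it.

Compound 1 (`COc1ccc(C(=O)c2ccc(OC)c3c2OC(C)(C)C=C3)c(NC(=O)CO)c1`) gives 230 nM in a functional assay on HCT-8 cells (Homo sapiens) for antiproliferative activity, read by MTT assay, with a stated time of 48 h (a lower number here means a stronger inhibitor, a higher number a weaker inhibitor), and compound 2 (`C=C(c1ccc2c(c1)C=CC(C)(C)O2)c1ccc(OC)cc1NC(=O)CO`) gives 220 nM there. Compound 2 stands level with compound 1, since the two numbers lie within the scatter of each other and cannot be ranked.

Compound 3 (`C=C(c1ccc2c(c1)C=CC(C)(C)O2)c1ccc(OC)cc1NC(=O)CNCC`) departs from compound 2 in one place (ethylamino in place of hydroxy on a saturated chain carbon bound to a carbonyl carbon) with ethylamino in place of hydroxy on a saturated chain carbon bound to a carbonyl carbon. Among the measured compounds shown here, no measured pair isolates a single change, so nothing yet shows how this assay responds to this exchange. The expectation rests only on compound 2 at 220 nM and on the structural change itself.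

A modest rise in the number is expected, which would make compound 3 a somewhat weaker inhibitor than compound 2, though with wide uncertainty. The expected change is a 2.0-fold higher number from compound 2 to compound 3 (0.31 log units; beyond the scatter) in that direction. For compound 3 the estimated value is 450 nM with an expected range of 120 nM to 1500 nM in this measurement.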

Compound 3, half-maximal inhibitory concentration: 2220 nM
The estimate for compound 3 lay 4.9-fold (0.69 log units) below the measured number; the whole stated range lies below it.
By their numbers in this assay, from the lowest: compounds 2 and 1 (each within the scatter of the next); then compound 3.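

In this assay the series now has its first step in a single place, and ethylamino in place of hydroxy on a saturated chain carbon bound to a carbonyl carbon gives a 10-fold higher number from compound 2 to compound 3 (1.00 log units; beyond the scatter), so this position does not accept every group alike. The counts of hydrogen-bond donors and acceptors match on the two sides of the exchange, and neither group carries a net charge, so those counts do not separate hydroxy from ethylamino; what does differ is the heavy-atom count and the nitrogen and carbon that replace the oxygen. Nothing available explains why the number rises at this position.

Among the compounds shown here, with only this pair, the step cannot be assigned to the nitrogen itself or to the ethyl chain on it; an unsubstituted amino group, a methoxy group or a longer alkylamino chain at the same place would help pull these apart. Going by these compounds, it also remains open whether the same exchange on the core of compound 1 would give a step of similar size, or whether the step belongs to the core of compound 2 alone.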